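Pyrazine acylhydrazones: cytotoxicity on mouse macrophage cells

A few compounds are considered here, and "the series" means these few. Any claim that something is new, unique, unknown or untested is made for them only; others in the source may bear on it.

Measured compounds:
compound 1 `O=C(N/N=C/c1ccccc1Br)c1cnccn1`: 100%
compound 2 `O=C(N/N=C/c1ccc(Br)cc1)c1cnccn1`: 100%
compound 3 `COc1ccccc1/C=N/NC(=O)c1cnccn1`: 100%

In an ADME assay on J774 cells (Mus musculus) for cytotoxicity, read by MTT assay, with a stated time of 48 h, tested at 100 ug/mL (on this read-out lower numbers stand for a stronger effect and higher numbers for a weaker effect at the one concentration tested), compound 1 gives 100%, compound 2 gives 100% and compound 3 gives 100%. Compound 1 and compound 2 are built from the same atoms joined differently; the difference between the two cores is not broken down here. Compound 3 arises from compound 1 by methoxy in place of bromo on an aromatic carbon and this gives no change at the digits printed from compound 1 to compound 3 (within the scatter).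

Compound 4 `COc1ccc(/C=N/NC(=O)c2cnccn2)cc1` is not yet measured. It arises from compound 2 by methoxy in place of bromo on an aromatic carbon, the same kind of change as from compound 1 to compound 3, except that the group sits para to a large group rather than ortho to a large group. Because compound 1 to compound 3 gave no change at the digits printed from compound 1 to compound 3 (within the scatter), the step is expected to be no change at the digits printed from compound 2 to compound 4 (within the scatter). Compound 4 is estimated at 100%, between 88% and 100%.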

Compound 4, a percentage reported as activity, at one concentration (the size of the read-out at that concentration, not a potency): 55%
Compound 4: the middle estimate sits 45 percentage points above what was measured, outside the stated range (below it).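

In this assay, methoxy in place of bromo on an aromatic carbon, para to a large group, gives a number 45 percentage points lower from compound 2 to compound 4 (beyond the scatter). This change therefore does not carry over with the same size between the core of compound 1 and the core of compound 2: the same change on two cores in this assay, no change at the digits printed (within the scatter) from compound 1 to compound 3 and a number 45 percentage points lower (beyond the scatter) from compound 2 to compound 4, 45 percentage points apart, beyond the scatter of two such steps

With one pair on each core, the data do not show what lies behind the gap, nor how the same change would behave on any further core. Open, as far as these compounds go, is how an amine, a carboxylic acid or a longer chain such as ethoxy would read in this place on the core of compound 2. Also open, from the compounds shown here alone, is whether any of them would stay level with compound 2 or fall towards compound 4.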